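This account rests on a few compounds, and the source may have more. Where it says the series, first, only, none or still open, it means among the compounds named here.

Measured compounds in an assay on membranes from Sf9 cells for displacement of a labelled ligand from histamine H2 receptor (Homo sapiens), read by scintillation counting, with a stated time of 60 min; a lower number here means a stronger inhibitor, a higher number a weaker inhibitor:
compound 1, `Cc1nc(N)sc1CCCN/C(N)=N/C(=O)NC(C)c1ccc(Br)cc1`: 30.2 nM
compound 2, `Cc1nc(N)sc1CCCN/C(N)=N/C(=O)NCc1ccco1`: 10.5 nM
compound 3, `Cc1ccc(CC(C)CNC(=O)/N=C(\N)NCCCc2sc(N)nc2C)cc1`: 72.4 nM

Compound 1 stands at the second highest of the three numbers in this assay: compound 2 gives a lower number and compound 3 a higher one, both differences lying beyond the usual scatter. Compound 4, `Cc1nc(N)sc1CCCN/C(N)=N/C(=O)NC(C)c1cccc(F)c1`, is not yet measured. It differs from compound 1 by 3-fluorophenyl in place of 4-bromophenyl on a saturated chain carbon bound to an amide-type nitrogen and a saturated chain carbon; the shared core and the chain are kept, only the aryl group changes. Going by the values given here, no pair of measured compounds shows a step of this kind, so no direction can be read from the measured values. The expected step is a 1.2-fold higher number from compound 1 to compound 4 (0.06 log units; within the scatter), not beyond the scatter. Compound 4 is estimated at 35 nM, with a range from 12 nM to 100 nM.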

Compound 4, inhibition constant: 2.04 nM
Compound 4: middle estimate off by 17-fold (1.23 log units), on the high side, and the stated range ends above it.
By their numbers in this assay, from the lowest: compound 4; then compound 2; then compound 1; then compound 3.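

In this assay, the aryl group on this saturated chain carbon strongly affects the number: 3-fluorophenyl in place of 4-bromophenyl gives a 15-fold lower number from compound 1 to compound 4 (1.17 log units; beyond the scatter). The step is large even though both groups have the same heavy-atom count, one carbon-only aromatic ring, and no hydrogen-bond donors or acceptors. No measured evidence bears on what lies behind this step. The compounds shown do not separate the change of halogen from the change of its place on the ring. Values for 3-bromophenyl and 4-fluorophenyl on this carbon would address that question.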